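Swapping the Acid Side Chain on Compound 3

A few compounds are considered here, and "the series" means these few. Any claim that something is new, unique, unknown or untested is made for them only; others in the source may bear on it.

Compound 1 `N=c1oc2ccc(Br)cc2cc1C(=O)NCC(O)CO`: 4%
Compound 2 `N=c1oc2ccc(Br)cc2cc1C(=O)NC1CCCCC1`: 10%
Compound 3 `COc1cccc2cc(C(=O)N[C@@H](CO)C(=O)O)c(=O)oc12`: 24%

In an assay on HEK293 cells for displacement of a labelled ligand from adenosine receptor A2b (Homo sapiens), read by scintillation counting, with a stated time of 30 min, tested at 10 uM (on this read-out higher numbers stand for more inhibition at the one concentration tested (going by the name of the read-out) and lower numbers for less inhibition), compound 3 stands highest of the three measured compounds, with compound 2 nearest and compound 1 furthest. Compound 4 `COc1cccc2cc(C(=O)NCC(O)CO)c(=O)oc12` keeps the core of compound 3 and changes only the amide side chain: 2,3-dihydroxypropyl in place of 1-carboxy-2-hydroxyethyl on an amide-type nitrogen. For the measured compounds named here, no measured step exchanges these two groups. Going by the values given here, the one step on an amide nitrogen, a number 6 percentage points higher from compound 1 to compound 2 (within the scatter), lies within the scatter and concerns a different core, so it gives little guidance. Compound 1 carries the 2,3-dihydroxypropyl group and shows a low value. A modest fall is therefore expected, a number 9 percentage points lower from compound 3 to compound 4 (within the scatter), and compound 4 is estimated at 15%, between 0% and 32%.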

Compound 4, a percentage reported as inhibition, at one concentration (the size of the read-out at that concentration, not a potency): 25%
Compound 4: middle estimate off by 10 percentage points, on the low side, and the stated range covers the measured number.
By their numbers in this assay, from the lowest: compounds 1 and 2 (each within the scatter of the next); then compounds 3 and 4 (each within the scatter of the next).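

Exchanging the 1-carboxy-2-hydroxyethyl group for 2,3-dihydroxypropyl on the amide-type nitrogen gives a number 1 percentage points higher from compound 3 to compound 4 (within the scatter) in this assay. For the compounds shown here, on this core, then, the first direct comparison of these two side chains shows no difference beyond the scatter, even though the group that enters has no carboxylic acid and no defined stereocentre. No available evidence explains this result. From the compounds shown here alone, what a chain ending in an amine, or a longer chain, would give on this nitrogen remains open. Also open, going by these compounds, is whether a change elsewhere on the shared core would move the number further.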